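Isopropyl to cyclopropyl on a weakly active compound

A few compounds are considered here, and "the series" means these few. Any claim that something is new, unique, unknown or untested is made for them only; others in the source may bear on it.

In a functional assay on HeLa cells (Homo sapiens) for antiproliferative activity, read by MTT assay, with a stated time of 72 h (a higher number here means a weaker inhibitor, a lower number a stronger inhibitor), compound 1 `COc1ncc(-c2ccc3c(c2)N(c2ccccc2)C(=O)CO3)cc1NS(=O)(=O)c1ccc(F)cc1` gives 1530 nM as its measured value, and compound 2 `CC(C)N1C(=O)COc2ccc(-c3cccc(NS(=O)(=O)c4ccc(F)cc4)c3)cc21` gives 22700 nM on the same scale. Compound 2 holds the higher of the two numbers, which makes it the weaker inhibitor of the pair, and the gap lies beyond the usual scatter of repeated measurements. These two compounds differ in more than one place, so their gap cannot be pinned on any single group. Compound 3 `O=C1COc2ccc(-c3cccc(NS(=O)(=O)c4ccc(F)cc4)c3)cc2N1C1CC1` is still unmeasured. It matches compound 2 except for one change, cyclopropyl in place of isopropyl on an amide-type nitrogen in a ring. Going by the values given here, no measured pair shows a change at this place, so the expectation rests on the structural change alone, and that change is a modest one. In this assay only a small move towards a lower number is expected, probably not beyond the scatter. In numbers, the expected change is a 1.5-fold lower number from compound 2 to compound 3 (0.18 log units; within the scatter) as a rough estimate. For compound 3 the estimated value is 15000 nM with an expected range from 5000 nM to 40000 nM in this test.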

Compound 3, half-maximal inhibitory concentration: > 40000 nM
Compound 3: only a limit was reported (the forecaster's own chance of this, stated with the estimate: 15%); middle value at least 2.6-fold (0.42 log units) from the limit.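

On this amide-type nitrogen, the first change seen at this position brings no move towards a lower number: in this assay compound 3 gives > 40000 nM, which is a limit of the assay and not a measured number. Replacing isopropyl with cyclopropyl keeps the same count of 3 carbon atoms and adds one three-membered ring, and the step reads an at least 1.7-fold higher number from compound 2 to compound 3 (0.24 log units; that floor lies within the scatter). That figure is only a floor and the real size of the step cannot be read, because compound 3 sits at a limit: the limit of > 40000 nM in this assay, at which 1 of the 3 values shown sits.

Compound 1 gives 1530 nM, yet it differs from compound 2 in more than one place, and no single group can be credited for that value. How this position would respond to a longer chain, such as one ending in an amine, or to a plain hydrogen on the nitrogen is not answered by the compounds shown.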